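Furan-to-thiophene swap on a pyridine-fused amide headgroup

This account rests on a few compounds, and the source may have more. Where it says the series, first, only, none or still open, it means among the compounds named here.

Within the data shown here, compound 2 `O=C(NCc1ccc(S(=O)(=O)c2cccc(C(F)(F)F)c2)cc1)c1cc2ccncc2o1` gives 5 nM in an assay for inhibition of Nicotinamide phosphoribosyltransferase (Homo sapiens), read by mass spectrometry, with stated times of 15 min and 30 min (on this read-out lower numbers stand for stronger inhibition and higher numbers for weaker inhibition), the lowest of the two numbers known; its neighbour compound 1 `O=C(NCc1ccc(S(=O)(=O)c2ccccc2)cc1)c1cc2ccncc2s1` gives 7 nM in this assay, a gap that lies within the scatter. Compound 3 `O=C(NCc1ccc(S(=O)(=O)c2cccc(C(F)(F)F)c2)cc1)c1cc2ccncc2s1` differs from compound 2 by a group of 9 heavy atoms (7 carbon, 1 nitrogen, 1 sulfur; one five-membered aromatic ring with 1 hetero atom, one six-membered aromatic ring with 1 hetero atom) in place of a group of 9 heavy atoms (7 carbon, 1 nitrogen, 1 oxygen; one five-membered aromatic ring with 1 hetero atom, one six-membered aromatic ring with 1 hetero atom), on a carbonyl carbon. Among the measured compounds shown here, no step between measured compounds isolates this exchange, but compound 1 carries the entering group and sits within the scatter of compound 2, so no step beyond the scatter is expected, a 1.2-fold higher number from compound 2 to compound 3 (0.08 log units; within the scatter). Compound 3 is estimated at 6 nM, with a range of 2.5 nM to 15 nM.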

Compound 3, half-maximal inhibitory concentration: 3 nM
Compound 3: the middle estimate sits 2.0-fold (0.30 log units) above what was measured, and the stated range covers the measured number.
By their numbers in this assay, from the lowest: compounds 3, 2 and 1 (each within the scatter of the next, the first and the last beyond it).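

In this assay, among these compounds, the exchange on a carbonyl carbon gives a 1.7-fold lower number from compound 2 to compound 3 (0.22 log units; within the scatter) and so stays within the scatter, which shows that the sulfur-containing group and the oxygen-containing group can be told apart by no measurable step here when trifluoromethyl is present. Trifluoromethyl in place of hydrogen on an aromatic carbon gives a 2.3-fold lower number from compound 1 to compound 3 (0.37 log units; beyond the scatter) as a modest step, the only one here beyond the scatter. Nothing measured here bears on the reason for either step.

From the compounds shown here alone, whether the exchange on the carbonyl carbon reads the same without trifluoromethyl remains open. So does how an amine or a carboxylic acid would read on that aromatic carbon.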